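A few compounds are considered here, and "the series" means these few. Any claim that something is new, unique, unknown or untested is made for them only; others in the source may bear on it.

In an ADME assay on L02 cells (Homo sapiens) for cytotoxicity, read by MTT assay, with a stated time of 72 h (on this read-out higher numbers stand for weaker inhibition and lower numbers for stronger inhibition), compound 1 `COc1cc(/C=C2\CN(C)C/C(=C\c3cc(OC)c(OC)c(OC)c3)C2=O)cc(OC)c1OC` gives 26400 nM. Compound 2 `COc1ccc(/C=C2\CN(C)C/C(=C\c3ccc(OC)c(OC)c3)C2=O)cc1OC` gives 18200 nM, which lies within the scatter of the value for compound 1. Compound 3 `CCN1C/C(=C\c2ccc(OC)c(OC)c2)C(=O)/C(=C/c2ccc(OC)c(OC)c2)C1` gives 9800 nM, a lower number than that of compound 1 by more than the scatter.

Compound 4 `COc1cc(/C=C2\CN(C(=O)c3ccccc3F)C/C(=C\c3cc(OC)c(OC)c(OC)c3)C2=O)cc(OC)c1OC` has not yet been measured. It keeps the core of compound 1 but carries (2-fluorophenyl)carbonyl in place of methyl on an amine nitrogen in a ring.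

Going by the values given here, only one measured step bears on that nitrogen, namely methyl in place of hydrogen on a saturated chain carbon bound to an amine nitrogen in a ring. That step is a 1.9-fold lower number from compound 2 to compound 3 (0.27 log units; within the scatter), within the scatter. Among the compounds with values here, no measured compound has a carbonyl group on that nitrogen, and the entering group is far larger than anything tested there, which leaves this step a weak guide. It gives no sign that a larger group there raises the number, so a moderate move toward a lower number is expected, though no real change remains possible. The expected change in this assay is a 2.9-fold lower number from compound 1 to compound 4 (0.47 log units; beyond the scatter). Compound 4 is estimated at 9000 nM, with an expected range of 2800 nM to 28000 nM.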

Compound 4, half-maximal inhibitory concentration: 4400 nM
Compound 4: middle estimate off by 2.0-fold (0.31 log units), on the high side; measured number inside the range.
By their numbers in this assay, from the lowest: compound 4; then compounds 3, 2 and 1 (each within the scatter of the next, the first and the last beyond it).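

In this assay, putting (2-fluorophenyl)carbonyl in place of methyl on the amine nitrogen in a ring gives a 6.0-fold lower number from compound 1 to compound 4 (0.78 log units; beyond the scatter), so this nitrogen takes a far larger group, with a carbonyl and an aromatic ring, and the number falls rather than rises. The one earlier step that bore on this nitrogen, a 1.9-fold lower number from compound 2 to compound 3 (0.27 log units; within the scatter), altered only a small chain on it and stayed within the scatter, so this is the first change here shown to move the number beyond the scatter. No measurement given here accounts for the fall in the number, and its origin within the entering group stays unexplained.

A single step cannot tell whether the carbonyl, the aromatic ring or the fluorine accounts for the change, and a benzoyl group without the fluorine, an acetyl group or a 2-fluorobenzyl group on the same nitrogen would separate these parts. Going by these compounds, it also remains open whether the same replacement would give a step of similar size on the core of compound 2, which carries fewer methoxy groups.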